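An Amide Group Leaves and Two Methyl Groups Enter

A few compounds are considered here, and "the series" means these few. Any claim that something is new, unique, unknown or untested is made for them only; others in the source may bear on it.

Among the compounds with values here, compound 1 `Cc1nc(-c2ccccc2)c(C(=O)N2CCN(c3cccc(C(N)=O)c3)CC2)o1` is the only compound in this set that comes with a number. In a functional assay on HL-60 cells (Homo sapiens) for inhibition, read by MTT assay, with a stated time of 72 h (a higher number here means a weaker inhibitor, a lower number a stronger inhibitor), compound 1 gives 71 nM. Compound 2 `COc1cccc(N2CCN(C(=O)c3oc(C(F)(F)F)nc3-c3ccc(F)cc3)CC2)c1` was also tested in this assay, where compound 2 is reported as "not active" (no number reported) without a number. Compound 2 differs from compound 1 in several places at once, so the two compounds do not form a one-point comparison.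

Compound 3 `Cc1cc(C)cc(N2CCN(C(=O)c3oc(C)nc3-c3ccccc3)CC2)c1` has not yet been measured. The change from compound 1 to compound 3 is 3,5-dimethylphenyl in place of 3-carbamoylphenyl on an amine nitrogen in a ring. Within the data shown here, no measured pair in this set differs in exactly one place, so the size of such a step cannot be read from data. The expectation for compound 3 in this assay is a step toward a weaker inhibitor, of about a 4.2-fold higher number from compound 1 to compound 3 (0.63 log units; beyond the scatter), with a real chance that no number is obtained at all. The estimated value for compound 3 in this assay is 300 nM, within a range from 60 nM to 3000 nM.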

Compound 3, half-maximal inhibitory concentration: 34.5 nM
Beside the measured number, compound 3's estimate is 8.7-fold (0.94 log units) above it; measured number outside the range, below it.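

In this assay, placing 3,5-dimethylphenyl on the amine nitrogen in the ring in place of 3-carbamoylphenyl gives a 2.1-fold lower number from compound 1 to compound 3 (0.31 log units; beyond the scatter). This shows that, on this core, the position can hold an aromatic ring with no hydrogen-bond donor or acceptor and still give a low number, so the amide of compound 1 is not required for strong inhibition in this cell assay; the step is modest, so the firmest reading is that the change is tolerated, not that it brings a large gain. No measurement here bears on why the number moved.

The compounds shown do not separate what the loss of the carbamoyl group contributes from what the arrival of the methyl groups contributes, and a plain phenyl or a 3-methylphenyl at this position would be needed to tell these apart. They also leave open how a carboxylic acid or an amine on this ring would behave, and which of the several differences in compound 2 goes with its lack of a number.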